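Spiro triazine aryl ethers: from methoxyphenyl to dichlorophenyl

The compounds below may be only part of what the source reports. "The series", "measured", "known", "first", "only" and "open" are said of these compounds alone.

Measured compounds:
compound 1 `COc1ccc(OCCCON2C(N)=NC(N)=NC23CCOCC3)cc1` — 11.1 nM
compound 2 `NC1=NC2(CCSCC2)N(OCCCOc2cccc(Cl)c2)C(N)=N1` — "not determined" (no result reported)
compound 3 `NC1=NC2(CCSCC2)N(OCCCOc2cc(Cl)c(Cl)cc2Cl)C(N)=N1` — "not determined" (no result reported)

In an assay on isolated protein for inhibition of Dihydrofolate reductase (Homo sapiens), read by spectrophotometry, using NADPH, with stated times of 5 s and 6 min (on this read-out higher numbers stand for weaker inhibition and lower numbers for stronger inhibition), compound 1 gives 11.1 nM. It stands alone on the numbers shown: compound 2 and compound 3 share the spiro triazine arrangement but carry a sulfur-containing saturated ring in place of the oxygen-containing one. In this assay, among the measured compounds shown here, compound 2 gives "not determined" (no result reported), and compound 3 gives "not determined" (no result reported), so no step between measured compounds can be drawn and nothing is known of how the chlorinated aryl ethers behave on this read-out.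

Compound 4 `NC1=NC2(CCOCC2)N(OCCCOc2ccc(Cl)cc2Cl)C(N)=N1` is the unmeasured compound. It keeps the core of compound 1 and the three-carbon linker, and differs only at the far end: 2,4-dichlorophenyl in place of 4-methoxyphenyl on an oxygen on a saturated carbon. For the measured compounds named here, with no measured step to lean on, the expectation rests on compound 1 alone, whose value in this assay is 11.1 nM. Compound 4 is expected to give a value close to that of compound 1, with the step from compound 1 to compound 4 estimated at a 1.6-fold lower number from compound 1 to compound 4 (0.20 log units; within the scatter), which is not beyond the usual scatter and leans, if anything, toward stronger inhibition. Compound 4 is therefore estimated at 7 nM, with a range from 2 nM to 30 nM.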

Compound 4, half-maximal inhibitory concentration: 7.46 nM
Estimate against measurement, compound 4: 1.1-fold (0.03 log units) below; the measured number falls inside the stated range.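

In this assay, putting 2,4-dichlorophenyl in place of 4-methoxyphenyl on an oxygen on a saturated carbon amounts to a 1.5-fold lower number from compound 1 to compound 4 (0.17 log units; within the scatter), so this read-out does not separate the two compounds. This gives the first number for a chlorinated aryl ether among the compounds shown, and it shows that, on the shared core and three-carbon linker, this position accepts a group with no hydrogen-bond acceptor in place of one with a single acceptor without a change beyond the scatter. Nothing on hand bears on why the two groups read alike.

Among the compounds shown here, no step to compound 2 or compound 3 can be read, so the sulfur-containing ring and the other chlorine patterns they carry remain without a comparison on this core. Also open, on these data alone, is how far this tolerance extends, since a single pair of aryl groups cannot show whether an amine or a carboxylic acid at the far end of the chain, or a longer chain in place of the three-carbon linker, would keep inhibition at this level.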